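A few compounds are considered here, and "the series" means these few. Any claim that something is new, unique, unknown or untested is made for them only; others in the source may bear on it.

Of the compounds shown here, three sharing one core have been tested in a functional assay on M14 cells (Homo sapiens) for cytotoxicity; a lower number here means a stronger inhibitor of growth, a higher number a weaker inhibitor of growth. Compound 3 (`CSc1ccc(C2=C(c3ccc(C)c(C)c3)C(=O)N3CCCC3C2)cc1`) gives 800 nM, the middle of the three numbers. Compound 2 (`CSc1ccc(C2=C(c3ccc(F)c(F)c3)C(=O)N3CCCC3C2)cc1`) gives 300 nM, and compound 1 (`COc1ccc(C2=C(c3ccc(SC)cc3)CC3CCCN3C2=O)cc1Br`) gives 3000 nM.

The next compound, compound 4 (`COc1ccc(C2=C(c3ccc(SC)cc3)CC3CCCN3C2=O)cc1`), has 4-methoxyphenyl in place of 3,4-dimethylphenyl on a double-bonded ring carbon. All three measured steps exchange the group on this same carbon, so all bear on the change. They are a 10-fold lower number from compound 1 to compound 2 (1.00 log units; beyond the scatter), a 3.8-fold lower number from compound 1 to compound 3 (0.57 log units; beyond the scatter) and a 2.7-fold higher number from compound 2 to compound 3 (0.43 log units; beyond the scatter), each modest but beyond the scatter.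

Of the groups tested there, the one closest to the entering 4-methoxyphenyl is the 3-bromo-4-methoxyphenyl of compound 1, which has the highest number at 3000 nM. Within the data shown here, no measured compound separates the share of the bromine from that of the methoxy group, so this comparison is only a loose guide. A small move towards a higher number is therefore expected in this assay, probably not beyond the scatter. The expected change is a 1.5-fold higher number from compound 3 to compound 4 (0.18 log units; within the scatter). For compound 4 the estimate is 1200 nM, with an expected range from 400 nM to 3000 nM.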

Compound 4, concentration for 50% growth inhibition: 4000 nM
Compound 4: middle estimate off by 3.3-fold (0.52 log units), on the low side; measured number outside the range, above it.
By their numbers in this assay, from the lowest: compound 2; then compound 3; then compounds 1 and 4 (each within the scatter of the next).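

In this assay, hydrogen in place of bromo on an aromatic carbon gives a step within the scatter (a 1.3-fold higher number from compound 1 to compound 4 (0.12 log units; within the scatter)), so the bromine, whose share could not be separated from that of the methoxy group before, accounts for little here. The 4-methoxyphenyl group therefore falls with the 3-bromo-4-methoxyphenyl group at the high end of the numbers for this double-bonded ring carbon, well clear of the 3,4-dimethylphenyl group (a 5.0-fold higher number from compound 3 to compound 4 (0.70 log units; beyond the scatter)) and further still from the 3,4-difluorophenyl group (a 13-fold higher number from compound 2 to compound 4 (1.12 log units; beyond the scatter)). Across these four compounds, both groups carrying a methoxy group give higher numbers than both groups without one, and no compound shown goes against this.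

There is no evidence on why the methoxy-bearing groups behave this way.

The compounds leave open whether the methoxy group matters through its oxygen or its size, which a 4-hydroxyphenyl, 4-ethoxyphenyl or 4-methylphenyl group on this carbon would help to show. They also leave open whether the lower number of compound 2 needs both fluorines or would hold with a single fluorine, as in a 4-fluorophenyl group.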